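Aromatic substituent changes and maximal response in the series

The source may hold more compounds than are shown below. What is called first, only, known or untested is meant among the compounds shown, and "the series" means these compounds.

Measured so far in an assay on HEK293 cells for activation of Kir3.1/Kir3.2 (Homo sapiens), read by thallium flux; a higher number here means a larger maximal response, a lower number a smaller maximal response:
compound 1, `Cc1cc(NC(=O)Cn2nnc(-c3cccc(Cl)c3)n2)n(C2CCCCC2)n1`: 89%
compound 2, `Cc1cc(NC(=O)Cn2nnc(-c3ccc(F)cc3)n2)n(C2CCCCC2)n1`: 92%
compound 3, `Cc1cc(NC(=O)Cn2nnc(-c3cccc(C(F)(F)F)c3)n2)n(C2CCCCC2)n1`: 86%

Compound 3 gives the lowest of the three numbers, yet the steps to it stay within the scatter: a number 3 percentage points lower from compound 1 to compound 3 (within the scatter) and a number 6 percentage points lower from compound 2 to compound 3 (within the scatter). The remaining step, a number 3 percentage points higher from compound 1 to compound 2 (within the scatter), is within the scatter as well. Compound 4, `Cc1cc(NC(=O)Cn2nnc(-c3cccc(C#N)c3)n2)n(C2CCCCC2)n1`, differs from compound 3 by cyano in place of trifluoromethyl on an aromatic carbon. Among the compounds with values here, no measured step covers this change; the three measured steps, all on the same aromatic carbon region, show no movement beyond the scatter. For compound 4 a step of a number 2 percentage points higher from compound 3 to compound 4 (within the scatter) in this assay is therefore expected, i.e. none beyond the scatter. Compound 4 is estimated at 88%, with a range from 76% to 100%.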

Compound 4, largest response reached (Emax), in percent of the reference or control that the assay uses: 80%
Compound 4: the middle estimate sits 8 percentage points above what was measured; the measured number falls inside the stated range.
By their numbers in this assay, from the lowest: compounds 4, 3, 1 and 2 (each within the scatter of the next, the first and the last beyond it).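

In this assay, within the data shown here, cyano on this aromatic carbon gives the first step beyond the scatter (a number 12 percentage points lower from compound 2 to compound 4 (beyond the scatter)). The other two steps to the nitrile (a number 6 percentage points lower from compound 3 to compound 4 (within the scatter); a number 9 percentage points lower from compound 1 to compound 4 (within the scatter)) remain within it, so the separation holds against the 4-fluorophenyl compound alone. Nothing available bears on the reason for this step.

The step from 4-fluorophenyl to 3-cyanophenyl changes group and place together, and the two stay unseparated. Going by these compounds, whether an amine or a carboxylic acid on this carbon would move the maximal response further remains open.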